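Acylguanidine series: benzyloxy in place of pentyl

The compounds below may be only part of what the source reports. "The series", "measured", "known", "first", "only" and "open" are said of these compounds alone.

Of the compounds shown here, three have been measured in a functional assay for inhibition of sodium/hydrogen exchanger (Oryctolagus cuniculus); a higher number here means a weaker inhibitor, a lower number a stronger inhibitor. Compound 1 `CS(=O)(=O)c1cc(C(=O)N=C(N)N)c(Cl)cc1Cl` gives 140 nM. Compound 2 `CCCCCc1cc(C)c(C(=O)N=C(N)N)cc1S(C)(=O)=O` gives 27 nM. Compound 3 `Cc1cc(-c2cc(C(F)(F)F)cc(C(F)(F)F)c2)c(S(C)(=O)=O)cc1C(=O)N=C(N)N` gives 2800 nM. Compound 2 has the lowest number of the three and is thus the strongest inhibitor: its gaps to compound 1, the nearest, and to compound 3, the furthest, both lie beyond the scatter.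

Compound 4 `Cc1cc(OCc2ccccc2)c(S(C)(=O)=O)cc1C(=O)N=C(N)N` is not yet measured in this assay. It differs from compound 2 as follows: benzyloxy in place of pentyl on an aromatic carbon.

For the measured compounds named here, no measured pair isolates this change. Where compound 2 carries pentyl, compound 3 carries a six-membered aromatic ring, and compound 3 gives 2800 nM, the highest number of the three. The benzyloxy group of compound 4 also brings a six-membered aromatic ring, so the expectation for compound 4 is a weakening step, a 4.4-fold higher number from compound 2 to compound 4 (0.65 log units; beyond the scatter), of moderate size, beyond the scatter but not reaching the number of compound 3. For compound 4 the estimate in this assay is 120 nM, within a range from 30 nM to 500 nM.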

Compound 4, half-maximal inhibitory concentration: 28 nM
For compound 4 the middle estimate is 4.3-fold (0.63 log units) above the measured one; measured number below the stated range.
By their numbers in this assay, from the lowest: compounds 2 and 4 (each within the scatter of the next); then compound 1; then compound 3.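

In this assay, benzyloxy in place of pentyl on this aromatic carbon, ortho to a methylsulfonyl group, gives a 1.0-fold higher number from compound 2 to compound 4 (0.02 log units; within the scatter), so the two groups cannot be told apart here even though benzyloxy brings a six-membered aromatic ring and a hydrogen-bond acceptor. A six-membered aromatic ring at this position therefore does not by itself bring a high number: compound 4 gives 28 nM, whereas compound 3, with its bis(trifluoromethyl)phenyl group, gives 2800 nM. No data on hand account for this result.

The compounds shown leave open what the oxygen of benzyloxy contributes, which a phenethyl group at this position would test. Also open, going by these compounds, are how far this position tolerates bulk on the benzyl ring, as with a trifluoromethyl-substituted benzyloxy group, and how an amine or a carboxylic acid would fare there.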